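The source may hold more compounds than are shown below. What is called first, only, known or untested is meant among the compounds shown, and "the series" means these compounds.

In an assay for positive allosteric modulation of metabotropic glutamate receptor 2 (Rattus norvegicus) (on this read-out lower numbers stand for an effect already at smaller amounts and higher numbers for an effect only at larger amounts of compound), compound 1, `Cc1cc(OC[C@H](C)COc2ccc(C(=O)CC(C)(C)C)c(O)c2C)ccc1C(=O)O`, gives 305 nM, and compound 2, `Cc1c(OC[C@@H](C)COc2ccc(C(=O)O)c(Cl)c2)ccc(C(=O)CC(C)(C)C)c1O`, gives 50 nM. Among the compounds with values here, compound 2 stands at the lower of the two numbers measured so far, the single step recorded being a 6.1-fold lower number from compound 1 to compound 2 (0.79 log units; beyond the scatter) in this assay, with chloro in place of methyl on an aromatic carbon.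

Compound 3, `COc1cc(OC[C@H](C)COc2ccc(C(=O)CC(C)(C)C)c(O)c2C)ccc1C(=O)O`, has not been measured. It differs from compound 2 by methoxy in place of chloro on an aromatic carbon. Within the data shown here, the only measured step that bears on this change is the one from compound 1 to compound 2, in which the same aromatic carbon carried methyl and then chloro; methoxy is a third group at that position, and no step among the measured compounds shows what it does there. Since the move from methyl to chloro lowered the number by a 6.1-fold lower number from compound 1 to compound 2 (0.79 log units; beyond the scatter), and methoxy is neither of these, the expectation for compound 3 is a number in this assay lying between those of compound 1 and compound 2, which means an expected step of a 3.0-fold higher number from compound 2 to compound 3 (0.48 log units; beyond the scatter). Compound 3 is therefore estimated at 150 nM in this assay, within a range from 50 nM to 450 nM.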

Compound 3, half-maximal effective concentration: 194 nM
For compound 3 the middle estimate is 1.3-fold (0.11 log units) below the measured one; measured number inside the range.
By their numbers in this assay, from the lowest: compound 2; then compounds 3 and 1 (each within the scatter of the next).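

At the aromatic carbon ortho to a carboxy group, this assay now allows three groups to be compared, and chloro no longer has only methyl as its reference, since the change to methoxy gives a 3.9-fold higher number from compound 2 to compound 3 (0.59 log units; beyond the scatter). Methoxy and methyl cannot be told apart at this carbon, with a 1.6-fold lower number from compound 1 to compound 3 (0.20 log units; within the scatter), so the lower number seen with chloro is not shared by either of the other two groups, even though methoxy differs from methyl by bringing in an oxygen that counts as a hydrogen-bond acceptor. Nothing in the available evidence accounts for chloro standing apart from methyl and methoxy.

The compounds shown leave open whether another halogen such as fluoro or bromo would stand with chloro at this carbon, or whether it would fall with methyl and methoxy. They also leave open how an amine, a hydroxy group or a longer ether such as ethoxy would behave there, and whether the same order of groups would hold on a core other than the one shared here.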